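Swapping the biaryl arm of compound 3

The source may report more compounds than this note shows. Statements on the series, on what has been measured and on what is new or still open speak of the compounds shown alone.

Values measured in a functional assay on HOS cells (Homo sapiens) for inhibition, with a stated time of 72 h; a higher number here means a weaker inhibitor, a lower number a stronger inhibitor:
- compound 1 `NC1CCC(Nc2nc(NCc3ccc(-n4cccn4)cc3)c3ncn(C4CCCC4)c3n2)CC1` gives 103 nM
- compound 2 `NC1CCC(Nc2nc(NCc3ccc(-c4ccco4)nc3)c3ncn(C4CCCC4)c3n2)CC1` gives 44 nM
- compound 3 `NC1CCC(Nc2nc(NCc3ccc(-c4ccsc4)nc3)c3ncn(C4CCCC4)c3n2)CC1` gives 89 nM

Compound 3 sits close to compound 1, and the measured steps show a 1.2-fold lower number from compound 1 to compound 3 (0.06 log units; within the scatter), a 2.0-fold higher number from compound 2 to compound 3 (0.31 log units; beyond the scatter) and a 2.3-fold lower number from compound 1 to compound 2 (0.37 log units; beyond the scatter). Compound 4 `NC1CCC(Nc2nc(NCc3cc(Cl)ccc3O)c3ncn(C4CCCC4)c3n2)CC1` has 5-chloro-2-hydroxyphenyl in place of 6-(thiophen-3-yl)pyridin-3-yl on a saturated chain carbon bound to a nitrogen on an aromatic ring. Each measured step exchanges one linked pair of aromatic rings for another, so none tests this loss of a ring. A higher number, larger than those steps, is therefore only tentatively expected. In this assay the expected outcome is a 2.8-fold higher number from compound 3 to compound 4 (0.45 log units; beyond the scatter), as an estimate only. Compound 4 is estimated at 250 nM (range 60 nM to 1000 nM).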

Compound 4, half-maximal inhibitory concentration: 490 nM
Estimate against measurement, compound 4: 2.0-fold (0.29 log units) below, and the stated range covers the measured number.
By their numbers in this assay, from the lowest: compound 2; then compounds 3 and 1 (each within the scatter of the next); then compound 4.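

Putting the single ring 5-chloro-2-hydroxyphenyl at this place, on a saturated chain carbon bound to a nitrogen on an aromatic ring, gives a 5.5-fold higher number from compound 3 to compound 4 (0.74 log units; beyond the scatter) and an 11-fold higher number from compound 2 to compound 4 (1.05 log units; beyond the scatter) and a 4.8-fold higher number from compound 1 to compound 4 (0.68 log units; beyond the scatter) in this assay and each of these is larger than any step among the linked ring pairs. All three compounds with two linked rings therefore give lower numbers than the one with a single ring. Nothing available explains this rise.

The change swaps the ring count and adds chlorine and hydroxyl at once, so their separate contributions remain unresolved. A plain phenyl or a pyridin-3-yl group at this place would help separate them.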